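The source may hold more compounds than are shown below. What is called first, only, known or untested is meant among the compounds shown, and "the series" means these compounds.

Measured in an ADME assay on Vero cells (Chlorocebus sabaeus) for antiproliferative activity, read by MTT assay, with a stated time of 72 h; on this read-out lower numbers stand for stronger inhibition and higher numbers for weaker inhibition:
Compound 1 `CN(c1ccc(Cl)cc1)S(=O)(=O)C1CC2OC1C(c1ccc(NC(=O)CCCCCCC(=O)O)cc1)=C2c1ccc(O)cc1`: > 100000 nM
Compound 2 `CCN(c1cccc(OC)c1)S(=O)(=O)C1CC2OC1C(c1ccc(NC(=O)CCCCCCC(=O)O)cc1)=C2c1ccc(O)cc1`: > 100000 nM

Compound 2 gives > 100000 nM in this assay, and this is a limit of the assay, not a number. It shares this position with compound 1, as the limit of > 100000 nM in this assay, at which 2 of the 2 values shown sit, shows.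

The next compound, compound 3 `CCN(c1ccc(Cl)cc1)S(=O)(=O)C1CC2OC1C(c1ccc(NC(=O)CCCCCCC(=O)O)cc1)=C2c1ccc(O)cc1`, keeps the ethyl group of compound 2 and changes the aryl group: 4-chlorophenyl in place of 3-methoxyphenyl on a sulfonamide nitrogen. In other words, 4-chlorophenyl stands in place of 3-methoxyphenyl on a sulfonamide nitrogen.

Among the compounds with values here, only one measured step bears on this change, a step that the two limits leave unreadable from compound 1 to compound 2. It has no readable size, so it gives no measured direction or magnitude for the aryl exchange. Compound 1 already carries 4-chlorophenyl on its sulfonamide nitrogen, and its > 100000 nM is likewise a limit. With both measured compounds at that limit, no step beyond the scatter is expected in this assay, and no direction can be assigned.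

The expected change is a number no higher from compound 2 to compound 3 (the limit leaves the size open). For compound 3 the estimated value is 100000 nM, within an expected range of 50000 nM to 200000 nM.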

Compound 3, half-maximal inhibitory concentration: > 100000 nM
Compound 3 was reported as a limit; the forecaster's own chance of this, stated with the estimate: 85%; the middle value lies on the limit itself.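

In this assay compound 3 gives > 100000 nM, which is a limit of the assay and not a number. No step linking compound 1, compound 2 and compound 3 can be read, and all three share one position: the limit of > 100000 nM in this assay, at which 3 of the 3 values shown sit.

The compounds shown leave open whether either change on the sulfonamide nitrogen, in its aryl group or in its methyl or ethyl group, alters the antiproliferative read-out at all.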